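This account rests on a few compounds, and the source may have more. Where it says the series, first, only, none or still open, it means among the compounds named here.

Of the compounds shown here, two built on a shared core have been tested in a functional assay on SH-SY5Y cells (Homo sapiens) for antiproliferative activity, read by MTT assay, with a stated time of 48 h; a lower number here means a stronger inhibitor of growth, a higher number a weaker inhibitor of growth. In this assay, compound 1 `COc1ccc(Cn2ncc(NCCOc3ccccc3OC)c(Cl)c2=O)cc1OC` gives 33100 nM. Compound 2 `COc1ccccc1OCCNc1cnn(Cc2ccc(OC(F)F)c(OC3CCCC3)c2)c(=O)c1Cl` gives > 100000 nM, which is a limit of the assay and not a number.

Compound 3 `COc1ccccc1OCCNc1cnn(Cc2ccc(OC)c(OC3CCCC3)c2)c(=O)c1Cl` has not yet been measured. It differs from compound 2 in a single place, with methyl in place of difluoromethyl on an oxygen on an aromatic ring. For the measured compounds named here, no measured pair shows what this swap does, so any forecast is loose. Compound 1, at 33100 nM, shows that a measurable number is possible among these compounds. Compound 3 could still end at the limit of the assay, as compound 2 does.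

A modest gain in growth inhibition is expected, with an estimated step of an at least 1.4-fold lower number from compound 2 to compound 3 (0.15 log units; that floor lies within the scatter). For compound 3, the estimated value is 70000 nM, with an expected range from 25000 nM to 100000 nM.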

Compound 3, concentration for 50% growth inhibition: 23300 nM
Beside the measured number, compound 3's estimate is 3.0-fold (0.48 log units) above it; measured number outside the range, below it.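

In this assay, for the compounds shown here, methyl in place of difluoromethyl on an oxygen on an aromatic ring gives an at least 4.2-fold lower number from compound 2 to compound 3 (0.63 log units; beyond the scatter), so this one place can move growth inhibition beyond the scatter, which the earlier compounds could not show. That step is a floor and not a full measure because compound 2 stands at a limit of the assay: the limit of > 100000 nM in this assay, at which 1 of the 3 values shown sits. A second change, cyclopentyl in place of methyl on an oxygen on an aromatic ring, gives a 1.4-fold lower number from compound 1 to compound 3 (0.15 log units; within the scatter), so it does not separate these two compounds in this assay.

The compounds shown leave open how an ethyl group, a longer chain or a trifluoromethyl group would read on this oxygen. They also leave open whether the step from difluoromethoxy to methoxy would keep its size on a different shared core.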